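Amino in place of hydrogen on compound 2

The source may report more compounds than this note shows. Statements on the series, on what has been measured and on what is new or still open speak of the compounds shown alone.

Of the compounds shown here, two have been measured so far. In a functional assay on HT-1080 cells (Homo sapiens) for antiproliferative activity, read by MTT assay, with a stated time of 72 h (on this read-out lower numbers stand for stronger inhibition and higher numbers for weaker inhibition), compound 1, `COc1ccc(-c2ss/c(=N/O)c2-c2cc(OC)c(OC)c(OC)c2)cc1N`, gives 9360 nM. Compound 2, `COc1ccc(-c2c(-c3cc(OC)c(OC)c(OC)c3)ss/c2=N/O)cc1`, stands at > 100000 nM, which is a limit of the assay and not a number. Its true position is therefore unknown, and any step from it has no fixed starting point.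

The next compound is compound 3, `COc1ccc(-c2c(-c3cc(OC)c(OC)c(OC)c3)ss/c2=N/O)cc1N`. It has amino in place of hydrogen on an aromatic carbon, ortho to a methoxy group, so that 4-methoxyphenyl becomes 3-amino-4-methoxyphenyl: amino in place of hydrogen on an aromatic carbon. Among the compounds with values here, no measured pair isolates this change, so the expectation rests on thin ground. Compound 1 also bears the 3-amino-4-methoxyphenyl group and reads 9360 nM, which makes it the only numerical anchor. In this assay the expected change is an at least 12-fold lower number from compound 2 to compound 3 (1.09 log units; beyond the scatter), towards stronger inhibition and beyond the scatter, although a result still at the limit remains possible. For compound 3 the estimated value is 8000 nM, with an expected range of 600 nM to 70000 nM.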

Compound 3, half-maximal inhibitory concentration: 2910 nM
Compound 3: middle estimate off by 2.7-fold (0.44 log units), on the high side; low and high end bracket the measured number.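

In this assay, amino in place of hydrogen on an aromatic carbon, ortho to a methoxy group, turns 4-methoxyphenyl into 3-amino-4-methoxyphenyl and gives an at least 34-fold lower number from compound 2 to compound 3 (1.53 log units; beyond the scatter), so this position now has a single change tied to a large step, which neither compound 1 nor compound 2 could show alone. Compound 2 stands at > 100000 nM, which is a limit of the assay and not a number. The step is therefore a lower bound, with a fixed end only on the side of compound 3, and its true size stays unknown: the limit of > 100000 nM in this assay, at which 1 of the 3 values shown sits.

The compounds shown leave open whether the step belongs to amino in particular or would also come with a hydroxyl group, a dimethylamino group or an acetamido group on the same carbon. On these data alone, compound 1 carries the same 3-amino-4-methoxyphenyl group, but no partner with 4-methoxyphenyl and otherwise identical structure stands beside it, so it remains open whether the step repeats in the arrangement of compound 1.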